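Methoxy substitution on the anilino ring of compound 1

The source may hold more compounds than are shown below. What is called first, only, known or untested is meant among the compounds shown, and "the series" means these compounds.

Measured so far:
- compound 1, `Cc1nc(SCC(=O)Nc2nc(-c3ccc(Cl)cc3)cs2)n(Nc2ccccc2)c1C` — 7790 nM
- compound 2, `Cc1ccc(Nn2c(SCC(=O)Nc3nc(-c4ccccc4)cs3)nc(C)c2C)cc1` — > 100000 nM

Two compounds have numbers or limits in a functional assay on LOX IMVI cells (Homo sapiens) for antiproliferative activity, read by sulforhodamine B assay, with a stated time of 48 h; on this read-out lower numbers stand for higher toxicity in this test and higher numbers for lower toxicity in this test. Within the data shown here, compound 1 gives 7790 nM, the only actual number in this assay. Compound 2 reaches only the limit of the assay, > 100000 nM, so no number is known for it; this is the limit of > 100000 nM in this assay, at which 1 of the 2 values shown sits. Among the measured compounds shown here, compounds 1 and 2 differ in more than one place, so their pair gives no single step; what they show is a number for compound 1 and a limit for compound 2.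

The next compound, compound 3, `COc1ccc(Nn2c(SCC(=O)Nc3nc(-c4ccc(Cl)cc4)cs3)nc(C)c2C)cc1`, is to be measured in this assay. It differs from compound 1 by methoxy in place of hydrogen on an aromatic carbon. For the measured compounds named here, no measured step of this kind exists, so the expectation rests on compound 1 alone and on the limit for compound 2. A loss beyond the scatter is expected, a 2.3-fold higher number from compound 1 to compound 3 (0.36 log units; beyond the scatter), since compound 2 shows only the limit > 100000 nM where its anilino ring carries a group. Compound 3 is expected to give 18000 nM, between 4500 nM and 70000 nM.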

Compound 3, concentration lethal to 50% of the cells: > 100000 nM
Compound 3 ended at the assay's limit (the forecaster's own chance of this, stated with the estimate: 30%); at least 5.5-fold (0.74 log units) between middle value and limit.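

In this assay, among these compounds, methoxy in place of hydrogen on the anilino ring, para to a large group, gives the first step that changes one place only: an at least 12-fold higher number from compound 1 to compound 3 (1.10 log units; beyond the scatter) is a large loss beyond the scatter, which shows that this position of compound 1 does not take a methoxy group without losing toxicity in this test. Compound 3 gives > 100000 nM, which is a limit of the assay and not a number. Compound 1 therefore remains the only compound with an actual number, and the series now sits mostly at the limit: the limit of > 100000 nM in this assay, at which 2 of the 3 values shown sit.

From the compounds shown here alone, whether the loss belongs to methoxy itself or would follow any group at this position stays open, and a fluorine atom, a hydroxyl group or an amine on the same ring carbon would help to separate those two readings. Going by these compounds, compound 2 differs from compound 1 in more than one place and cannot settle this, and the other carbons of the anilino ring remain open as well.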